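The source may hold more compounds than are shown below. What is called first, only, known or untested is meant among the compounds shown, and "the series" means these compounds.

Measured compounds in a functional assay on the whole organism for activation, with Mus musculus as the target; a lower number here means that less compound is needed, a higher number that more compound is needed for the effect:
- compound 1 `CSc1nc(N)c2nc(O)n(Cc3ccccc3)c2n1` gives 0.1 mg/kg
- compound 2 `Nc1nc(O)nc2c1nc(O)n2Cc1ccccc1` gives 1 mg/kg
- compound 3 `Nc1ncnc2c1nc(O)n2Cc1ccccc1` gives 30 mg/kg

Compound 3 stands highest of the three numbers; its nearest neighbour is compound 2 a 30-fold higher number from compound 2 to compound 3 (1.48 log units; beyond the scatter), and its furthest is compound 1 a 300-fold higher number from compound 1 to compound 3 (2.48 log units; beyond the scatter). Compound 4 `CCCSc1nc(N)c2nc(O)n(Cc3ccccc3)c2n1` differs from compound 3 in one place: propylsulfanyl in place of hydrogen on an aromatic carbon.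

Among the measured compounds shown here, the step that bears on this is the one from compound 1 to compound 3 a 300-fold higher number from compound 1 to compound 3 (2.48 log units; beyond the scatter), which the change in hand reverses in kind, with propylsulfanyl rather than methylsulfanyl entering. A large step downward in this assay is therefore expected for compound 4 a 100-fold lower number from compound 3 to compound 4 (2.00 log units; beyond the scatter), though the longer chain leaves room for it to fall short of a full reversal. Compound 4 is estimated at 0.3 mg/kg, in the range 0.05 mg/kg to 2 mg/kg.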

Compound 4, minimum effective dose: 0.1 mg/kg
Compound 4: middle estimate off by 3.0-fold (0.48 log units), on the high side; the measured number falls inside the stated range.
By their numbers in this assay, from the lowest: compounds 1 and 4 (each within the scatter of the next); then compound 2; then compound 3.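

In this assay the aromatic carbon between two ring nitrogen atoms takes propylsulfanyl in place of hydrogen with a 300-fold lower number from compound 3 to compound 4 (2.48 log units; beyond the scatter) and in place of hydroxy with a 10-fold lower number from compound 2 to compound 4 (1.00 log units; beyond the scatter) as well. Going from methylsulfanyl to propylsulfanyl gives no change at the digits printed from compound 1 to compound 4 (within the scatter) and so, across these two groups, the large gain over hydrogen survives the longer chain. No measured evidence accounts for this.

Open, on these data alone, is whether a chain longer than propylsulfanyl keeps this number. Also open, as far as these compounds go, is whether an amine or a methoxy group on the same carbon matches the two sulfur-linked groups.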